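A methyl in place of fluoro on compound 2

The source may hold more compounds than are shown below. What is called first, only, known or untested is meant among the compounds shown, and "the series" means these compounds.

Measured in an ADME assay on RAW264.7 cells (Mus musculus) for cytotoxicity, read by MTT assay, with a stated time of 24 h, in the presence of a further agent that is not named here; a higher number here means a weaker inhibitor, a lower number a stronger inhibitor:
Compound 1 `CCC(C)Oc1ccc(C(O)C2OC(=O)c3c(OC)cc(OC)cc32)cc1`: > 40000 nM, a limit
Compound 2 `COc1cc(OC)c2c(c1)C(C(O)c1ccc(OCc3ccc(F)cc3)cc1)OC2=O`: > 40000 nM, a limit

Compound 2 has no exact number, only the limit > 40000 nM. Compound 3 `COc1cc(OC)c2c(c1)C(C(O)c1ccc(OCc3ccc(C)cc3)cc1)OC2=O` carries methyl in place of fluoro on an aromatic carbon. Among the compounds with values here, the only measured step is a step that the two limits leave unreadable from compound 1 to compound 2, so it offers no size to carry over. Both measured compounds sit at the limit of > 40000 nM in this assay, at which 2 of the 2 values shown sit, so another limit seems likely, and no step beyond the scatter is expected in this assay. The estimate means a number no higher from compound 2 to compound 3 (the limit leaves the size open), expected to stay within the scatter. For compound 3 the expected value is 40000 nM, with an estimated range of 20000 nM to 80000 nM.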

Compound 3, half-maximal inhibitory concentration: > 40000 nM
Compound 3: only a limit was reported (the forecaster's own chance of this, stated with the estimate: 85%); the middle value sits exactly at the limit.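

Within the data shown here, compound 3 ends at a limit, as do compound 1 and compound 2, so no step among the three can be read: the limit of > 40000 nM in this assay, at which 3 of the 3 values shown sit. The compounds shown leave open whether any change at these places would give an exact number in this assay at all.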